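Notes: aryl change from compound 3 to compound 4

This account rests on a few compounds, and the source may have more. Where it says the series, first, only, none or still open, it means among the compounds named here.

Measured in a functional assay on LoVo cells (Homo sapiens) for inhibition, read by MTT assay, with a stated time of 24 h; a lower number here means a stronger inhibitor, a higher number a weaker inhibitor:
compound 1 `CC1(C)[C@H]2CC[C@]1(C)N(Cc1cn(-c3ccccc3Br)nn1)C(=O)C2`: 60 nM
compound 2 `CC1(C)[C@H]2CC[C@]1(C)N(Cc1cn(-c3ccccc3Cl)nn1)C(=O)C2`: 190 nM
compound 3 `CC1(C)[C@H]2CC[C@]1(C)N(Cc1cn(-c3ccc(Cl)cc3)nn1)C(=O)C2`: 160 nM

Compound 3 gives 160 nM and cannot be separated from compound 2, the step being a 1.2-fold lower number from compound 2 to compound 3 (0.07 log units; within the scatter). Compound 1 holds the lowest number of the three, and the gap to it is a 2.7-fold higher number from compound 1 to compound 3 (0.43 log units; beyond the scatter).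

Compound 4 `COc1cccc(-n2cc(CN3C(=O)C[C@@H]4CC[C@@]3(C)C4(C)C)nn2)c1` carries 3-methoxyphenyl in place of 4-chlorophenyl on an aromatic nitrogen. Going by the values given here, no compound with a methoxy group has been measured, so the evidence is indirect. Among the compounds with values here, the closest precedent is the swap between two chlorophenyl groups, a 1.2-fold lower number from compound 2 to compound 3 (0.07 log units; within the scatter), which stayed within the scatter. The exchange of bromo for chloro on the same aryl position, a 3.2-fold higher number from compound 1 to compound 2 (0.50 log units; beyond the scatter), shows that a change on this ring can still produce a modest step. On that basis, no step beyond the scatter is expected in this assay, although a modest move in either direction remains possible. The expected step is a 1.1-fold higher number from compound 3 to compound 4 (0.05 log units; within the scatter). The estimate for compound 4 is 180 nM, with an expected range of 70 nM to 450 nM.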

Compound 4, half-maximal inhibitory concentration: 80 nM
For compound 4 the middle estimate is 2.3-fold (0.35 log units) above the measured one; the range from low to high includes it.
By their numbers in this assay, from the lowest: compounds 1, 4, 3 and 2 (each within the scatter of the next, the first and the last beyond it).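

In this assay, going by these compounds alone, 3-methoxyphenyl on the aromatic nitrogen brings an oxygen-bearing group to this position for the first time, and a 2.0-fold lower number from compound 3 to compound 4 (0.30 log units; within the scatter) and a 1.3-fold higher number from compound 1 to compound 4 (0.12 log units; within the scatter) both stay within the scatter, so neither 4-chlorophenyl nor 2-bromophenyl can be separated from it. Only the comparison with 2-chlorophenyl goes beyond the scatter, at a 2.4-fold lower number from compound 2 to compound 4 (0.38 log units; beyond the scatter), which shows that a halogen on this aryl group is not required for a number in the range of the best compound shown. Nothing available explains these steps, so the result remains a plain observation of what the aryl exchange does in this cell read-out.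

The compounds shown leave open whether the number follows the methoxy group itself or its place on the aryl group, as the series holds a single methoxyphenyl example. Also open, going by these compounds, is how an amine, a carboxylic acid or a longer alkoxy chain on the aryl group would read in this assay.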